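This account rests on a few compounds, and the source may have more. Where it says the series, first, only, none or still open, it means among the compounds named here.

Notes on a series of sulfamoyl nucleosides carrying acyl side chains, followed in an ADME assay on MRC5 cells (Homo sapiens) for antiproliferative activity, read by sulforhodamine B assay, with a stated time of 72 h; on this read-out higher numbers stand for weaker inhibition and lower numbers for stronger inhibition. Compound 1 `CC(C)C[C@H](O)C(=O)NS(=O)(=O)OC[C@H]1O[C@@H](n2cnc3c(N)ncnc32)[C@H](O)[C@@H]1O` has been measured there and gives 16700 nM. Compound 2 `CC(C)[C@@H](O)[C@H](O)C(=O)NS(=O)(=O)OC[C@H]1O[C@@H](n2cnc3c(=O)[nH]cnc32)[C@H](O)[C@@H]1O` returns only a limit in this assay, namely > 20000 nM. On the numbers shown, compound 2 therefore stands at the limit of > 20000 nM in this assay, at which 1 of the 2 values shown sits, without a number attached to it, and it is the one of the two measured compounds for which no number is known.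

Compound 3 `CC(C)C[C@H](O)C(=O)NS(=O)(=O)OC[C@H]1O[C@@H](n2cnc3c(=O)[nH]cnc32)[C@H](O)[C@@H]1O` has not yet been measured in this assay. Relative to compound 2, it carries hydrogen in place of hydroxy on a saturated chain carbon bound to two saturated chain carbons. Within the data shown here, no step between two measured compounds is recorded in this assay, so the size of this change has no precedent in the data. Starting from a limit, a move beyond the scatter in either direction cannot be argued for. The expected step in this assay is a step that the limit leaves unreadable from compound 2 to compound 3, which means hardly any change. For compound 3 the expected value in this assay is 25000 nM, with a range from 12000 nM to 60000 nM, and a fair chance that again only a limit is reported.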

Compound 3, half-maximal inhibitory concentration: > 20000 nM
Compound 3 gave a limit, no number; the forecaster's own chance of this, stated with the estimate: 65%; the middle value lies beyond the limit too.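

Exchanging 1-hydroxy-2-methylpropyl for isobutyl, on a saturated chain carbon bound to two saturated chain carbons, leaves compound 3 at a limit in this assay, as compound 2 was, so the step between these two cannot be read and this hydroxy shows no measurable effect here: the limit of > 20000 nM in this assay, at which 2 of the 3 values shown sit.

Among these compounds, with the isobutyl side chain held constant, the exchange of the aromatic group on a saturated ring carbon gives an at least 1.1-fold higher number from compound 1 to compound 3 (0.07 log units; that floor lies within the scatter), the first step with any readable size, though it is only a floor and does not clear the usual scatter. Among the compounds shown here, compound 1 therefore remains the only compound with a number, and neither side chain gives a number with the aromatic group of compound 2 and compound 3.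

The compounds shown leave open how far the values of compound 2 and compound 3 lie past the limit, and whether the hydroxy matters when it is paired with the aromatic group of compound 1. They also leave open whether an amine, a carboxylic acid or a longer chain in place of isobutyl would bring this aromatic group to a measurable value.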